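The source may hold more compounds than are shown below. What is called first, only, known or untested is meant among the compounds shown, and "the series" means these compounds.

Compound 1 `c1ccc(COc2ccccc2Nc2ncnc3cc4c(cc23)OCCOCCO4)cc1` was tested in a functional assay on MCF7 cells (Homo sapiens) for antiproliferative activity, read by MTT assay, with a stated time of 72 h (on this read-out higher numbers stand for weaker inhibition and lower numbers for stronger inhibition), and gave only a limit, > 100000 nM, so its true strength is not pinned down by a number. That limit is where compound 1 stands on the values shown here (the limit of > 100000 nM in this assay, at which 1 of the 2 values shown sits), and one of the two measured values sits there. Compound 2 `O=[N+]([O-])c1ccc(COc2cccc(Nc3ncnc4cc5c(cc34)OCCOCCOCCOCCO5)c2)cc1` is the other measured compound; in this assay compound 2 gives 6410 nM. Among the measured compounds shown here, no single-point step connects compound 1 and compound 2, since they differ in more than one place, so their two values simply show one compound at the limit and one with a numbered result.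

Compound 3 `O=[N+]([O-])c1ccc(COc2ccccc2Nc2ncnc3cc4c(cc23)OCCOCCO4)cc1` is not yet measured. It differs from compound 1 by nitro in place of hydrogen on an aromatic carbon, in words: nitro in place of hydrogen on an aromatic carbon. For the measured compounds named here, with compound 1 resting at a limit, no measured step shows what this change does. The expected step from compound 1 to compound 3 is estimated as an at least 1.6-fold lower number from compound 1 to compound 3 (0.22 log units; that floor lies within the scatter), toward stronger inhibition but modest. Compound 3 is therefore expected to give 60000 nM, with a range from 8000 nM to 200000 nM.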

Compound 3, half-maximal inhibitory concentration: > 100000 nM
Compound 3: no number, only a limit; the forecaster's own chance of this, stated with the estimate: 50%; middle value at least 1.6-fold (0.22 log units) from the limit.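

In this assay compound 3 gives > 100000 nM and this is a limit, not a number. Among the compounds shown here, compound 1 also rests at a limit, and no step between compound 1 and compound 3 can be read. The compounds shown leave open whether nitro in place of hydrogen on an aromatic carbon changes the strength of inhibition at all.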